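The compounds below may be only part of what the source reports. "The series", "measured", "known", "first", "only" and "open" are said of these compounds alone.

Measured so far in a functional assay on HEK293 cells for antagonist activity at transient receptor potential cation channel subfamily V member 1 (Rattus norvegicus); a higher number here means a weaker inhibitor, a lower number a stronger inhibitor:

Compound 1 `CC(C)c1ccc(NC(=O)N2CCN(c3ncccc3Cl)CC2)cc1` gives 11.5 nM.
Compound 2 `CC(C)c1ccc(NC(=O)N2CCN(c3ncccc3C(F)F)CC2)cc1` gives 27.7 nM.

For the measured compounds named here, of these two numbers compound 2 holds the higher one; the only step known is a 2.4-fold higher number from compound 1 to compound 2 (0.38 log units; beyond the scatter). Compound 3 `CC(C)c1ccc(NC(=O)N2CCN(c3ncccc3C=O)CC2)cc1` is not yet measured. The change from compound 2 is formyl in place of difluoromethyl on an aromatic carbon. Going by the values given here, no measured step replaces a difluoromethyl group with a formyl group, so the one step known, a 2.4-fold higher number from compound 1 to compound 2 (0.38 log units; beyond the scatter), bears on it only as a guide to how much a change at this position has moved the number. For compound 3 the expected step is a 1.4-fold higher number from compound 2 to compound 3 (0.16 log units; within the scatter), a modest rise or none beyond the scatter. Compound 3 is estimated at 40 nM, within 12 nM to 130 nM.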

Compound 3, half-maximal inhibitory concentration: 201 nM
The estimate for compound 3 lay 5.0-fold (0.70 log units) below the measured number; measured number above the stated range.
By their numbers in this assay, from the lowest: compound 1; then compound 2; then compound 3.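

In this assay this position proves far less tolerant than the first pair suggested: formyl for difluoromethyl gives a 7.3-fold higher number from compound 2 to compound 3 (0.86 log units; beyond the scatter), well beyond the earlier 2.4-fold higher number from compound 1 to compound 2 (0.38 log units; beyond the scatter). Set against chloro, formyl gives a 17-fold higher number from compound 1 to compound 3 (1.24 log units; beyond the scatter), so among these three groups the number climbs from chloro through difluoromethyl to formyl. No evidence at hand explains this order. Still open, from the compounds shown here alone, is where a nitrile, a methyl group, a hydroxymethyl group or a carboxylic acid would fall in that order, and whether any would match chloro.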